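Swapping a sulfamoylphenyl for a pyrazolyl group

The compounds below may be only part of what the source reports. "The series", "measured", "known", "first", "only" and "open" are said of these compounds alone.

Three measured compounds share a core that carries a carboxymethyl group and a varying aryl substituent. Compound 1 `O=C(O)Cc1sc(C(c2ccc(F)cc2)c2ccc(F)cc2)nc1-c1cc(F)cc(F)c1` gives 35 nM in an in vitro assay on HEK385-7 cells for displacement of a labelled ligand from prostaglandin D2 receptor 2 (Homo sapiens); on this read-out lower numbers stand for stronger inhibition and higher numbers for weaker inhibition. Compound 2 `O=C(O)Cc1sc(C(c2ccc(F)cc2)c2ccc(F)cc2)nc1-c1ccnc(N2CCC2)c1` gives 660 nM in this assay, and compound 3 `NS(=O)(=O)c1cccc(-c2nc(C(c3ccc(F)cc3)c3ccc(F)cc3)sc2CC(=O)O)c1` gives 140 nM in this assay. Compound 3 therefore stands second highest of the three numbers: there is a 4.0-fold higher number from compound 1 to compound 3 (0.60 log units; beyond the scatter), and there is a 4.7-fold lower number from compound 2 to compound 3 (0.67 log units; beyond the scatter).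

Compound 4 `O=C(O)Cc1sc(C(c2ccc(F)cc2)c2ccc(F)cc2)nc1-c1cn[nH]c1` has not yet been measured. It differs from compound 3 at the same position that varies across the measured set: 1H-pyrazol-4-yl in place of 3-sulfamoylphenyl on an aromatic carbon.

Within the data shown here, two measured steps bear on this change, since both alter the same aryl group. The step of a 19-fold higher number from compound 1 to compound 2 (1.28 log units; beyond the scatter) shows that a six-membered ring with a ring nitrogen and a basic substituent weakens binding considerably, while a 4.0-fold higher number from compound 1 to compound 3 (0.60 log units; beyond the scatter) shows a modest loss for the sulfamoyl-bearing ring. Among the measured compounds shown here, a small five-membered ring with two nitrogens and a hydrogen-bond donor has no direct precedent here, so a modest weakening relative to compound 3 seems the most likely outcome, with wide uncertainty. Compound 4 is expected to give 300 nM, within an estimated range from 80 nM to 1200 nM. The expected step is thus a 2.1-fold higher number from compound 3 to compound 4 (0.33 log units; beyond the scatter).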

Compound 4, half-maximal inhibitory concentration: 16 nM
The estimate for compound 4 lay 19-fold (1.27 log units) above the measured number; the measured number lies below the stated range.
By their numbers in this assay, from the lowest: compound 4; then compound 1; then compound 3; then compound 2.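

In this assay compound 4 has the lowest number of the four, set apart from each of the others: the change from the sulfamoyl-bearing ring (an 8.8-fold lower number from compound 3 to compound 4 (0.94 log units; beyond the scatter)), from the difluorinated ring (a 2.2-fold lower number from compound 1 to compound 4 (0.34 log units; beyond the scatter)) and from the azetidinyl-bearing ring (a 41-fold lower number from compound 2 to compound 4 (1.62 log units; beyond the scatter)). The earlier compounds shown here all carried a six-membered aromatic ring here, and compound 4 shows that this place, next to the ring nitrogen and next to the ring atom that bears the carboxymethyl group, also accepts a five-membered aromatic ring with 2 hetero atoms, of 5 heavy atoms, fewer than in the 3-sulfamoylphenyl group, with a lower number; the 1 hydrogen-bond donor counted on each of these two groups does not separate compound 3 from compound 4. No measurement at hand explains why the number falls.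

The compounds shown leave open whether the hydrogen on the pyrazole nitrogen matters, which a methyl group on that nitrogen would test. They also leave open how an imidazole or a triazole would compare at this place.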